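Fluoro in Place of Methyl on the Aryl Group

A few compounds are considered here, and "the series" means these few. Any claim that something is new, unique, unknown or untested is made for them only; others in the source may bear on it.

Three measured compounds share one core, and they differ only in the group attached to an aromatic nitrogen at its far end. Compound 1 `C/C(=C\CC/C(C)=C/CC[C@@H]1[C@@]2(C)CCC(=O)C(C)(C)[C@H]2CC[C@@]1(C)O)CC/C=C(\C)C(=O)OCc1cn(-c2ccc([N+](=O)[O-])cc2)nn1` carries 4-nitrophenyl, compound 2 `C/C(=C\CC/C(C)=C/CC[C@@H]1[C@@]2(C)CCC(=O)C(C)(C)[C@H]2CC[C@@]1(C)O)CC/C=C(\C)C(=O)OCc1cn(C[C@@H]2O[C@H](n3ccc(=O)[nH]c3=O)C[C@H]2O)nn1` a larger sugar-like group, and compound 3 `C/C(=C\CC/C(C)=C/CC[C@@H]1[C@@]2(C)CCC(=O)C(C)(C)[C@H]2CC[C@@]1(C)O)CC/C=C(\C)C(=O)OCc1cn(-c2ccccc2C)nn1` 2-methylphenyl. In a functional assay on DU-145 cells (Homo sapiens) for antiproliferative activity, read by MTT assay, with a stated time of 48 h (a higher number here means a weaker inhibitor, a lower number a stronger inhibitor), compound 3 gives only a limit of the assay, > 150000 nM. Compound 1 likewise reaches only a limit, > 150000 nM. Compound 2 gives a true number, 33100 nM. The step that the two limits leave unreadable from compound 1 to compound 3 cannot be read, because the limit of > 150000 nM in this assay, at which 2 of the 3 values shown sit, caps both of its ends. Compound 4 `C/C(=C\CC/C(C)=C/CC[C@@H]1[C@@]2(C)CCC(=O)C(C)(C)[C@H]2CC[C@@]1(C)O)CC/C=C(\C)C(=O)OCc1cn(-c2ccccc2F)nn1` differs from compound 3 in one place: fluoro in place of methyl on an aromatic carbon. No readable measured step bears on this change, and both aryl-bearing compounds sit at the limit. The expected step of a number no higher from compound 3 to compound 4 (the limit leaves the size open) is therefore none that could be seen beyond the scatter. Compound 4 is estimated at 150000 nM, within 50000 nM to 400000 nM, and most likely it too will return only a limit.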

Compound 4, half-maximal inhibitory concentration: > 150000 nM
Compound 4 ended at the assay's limit; the forecaster's own chance of this, stated with the estimate: 80%; the middle value sits exactly at the limit.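

The steps linking compound 4 with compound 3 and with compound 1 cannot be read, because both ends of each are capped: the limit of > 150000 nM in this assay, at which 3 of the 4 values shown sit.

On these data alone, whether 2-fluorophenyl and 2-methylphenyl truly differ in this assay stays open, as does how either compares with 4-nitrophenyl.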